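From Methyl to Diethylamino on Compound 2

The compounds below may be only part of what the source reports. "The series", "measured", "known", "first", "only" and "open" are said of these compounds alone.

In a functional assay on A-375 cells (Homo sapiens) for antiproliferative activity, read by trypan blue exclusion and crystal violet staining, with a stated time of 72 h (a lower number here means a stronger inhibitor, a higher number a weaker inhibitor), compound 2 `CCCC(=O)NC(c1ccc(C)cc1)c1cc(Cl)c2cccnc2c1O` gives 120 nM, the lowest of the two numbers available. Compound 1 `O=C(NCc1ccc2cccnc2c1O)C1CCCCC1` gives 910 nM, a number higher by more than the scatter, while compound 3 `CCCCC(=O)NCc1ccc2cccnc2c1O` shows only "nd" (no result reported), with no result reported. Compound 4 `CCCC(=O)NC(c1ccc(N(CC)CC)cc1)c1cc(Cl)c2cccnc2c1O` keeps the rest of compound 2 but carries diethylamino in place of methyl on an aromatic carbon, para to a large group: diethylamino in place of methyl on an aromatic carbon. Among the measured compounds shown here, no measured pair of compounds shows a change of this kind, so the expectation rests on little. In this assay a small rise in the number is expected, within the scatter. The estimated step is a 1.3-fold higher number from compound 2 to compound 4 (0.10 log units; within the scatter). For compound 4 the estimate is 150 nM, with an expected range of 40 nM to 600 nM.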

Compound 4, half-maximal inhibitory concentration: 130 nM
Beside the measured number, compound 4's estimate is 1.2-fold (0.06 log units) above it; low and high end bracket the measured number.
By their numbers in this assay, from the lowest: compounds 2 and 4 (each within the scatter of the next); then compound 1.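

In this assay, among the compounds shown here, the change of methyl to diethylamino on this aromatic carbon gives a 1.1-fold higher number from compound 2 to compound 4 (0.03 log units; within the scatter) and is the first comparison at this position. Five heavy atoms, one of them nitrogen, can stand where a single carbon stood without moving the number beyond the scatter. Nothing available explains this result.

On these data alone, what a carboxylic acid or a simple amine on the same carbon would do remains open. So does whether a longer chain, such as hexyl, would fit here as well.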